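Working notes: from compound 1 to compound 4

The source may hold more compounds than are shown below. What is called first, only, known or untested is meant among the compounds shown, and "the series" means these compounds.

Measured in a functional assay on MDA-MB-231 cells (Homo sapiens) for cytotoxicity, read by MTT assay, with a stated time of 24 h; a lower number here means a stronger inhibitor, a higher number a weaker inhibitor:
- compound 1 `COc1ccc(/C=C2\CN(Cc3cn(Cc4cccc(Cl)c4)nn3)C/C(=C\c3ccc(OC)cc3)C2=O)cc1`: 98000 nM
- compound 2 `O=C1/C(=C/c2ccccc2F)CN(C(=S)SCc2cn(Cc3ccccc3Cl)nn2)C/C1=C\c1ccccc1F`: 100000 nM
- compound 3 `Cc1ccc(/C=C2\CN(C(=S)SCc3cn(Cc4ccccc4F)nn3)C/C(=C\c3ccc(C)cc3)C2=O)cc1`: 91500 nM

Compound 1, at 98000 nM, sits in the middle of these three numbers, and compound 2 and compound 3 both lie within the scatter of it. Compound 4 `COc1ccc(/C=C2\CN(Cc3cn(Cc4ccc(F)cc4)nn3)C/C(=C\c3ccc(OC)cc3)C2=O)cc1` keeps the core of compound 1 and carries 4-fluorophenyl in place of 3-chlorophenyl on a saturated chain carbon bound to an aromatic nitrogen. The same difference reads as 3-chlorobenzyl to 4-fluorobenzyl.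

For the measured compounds named here, no pair of measured compounds isolates this change, so the series offers no direct guide to it. The three measured compounds differ from one another in several places, yet their values in this assay stay within the scatter of each other. On that basis, no step beyond the scatter is expected, in either direction. The expected step is a 1.1-fold lower number from compound 1 to compound 4 (0.04 log units; within the scatter). For compound 4 the estimated value is 90000 nM, with an expected range of 40000 nM to 150000 nM.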

Compound 4, half-maximal inhibitory concentration: 70700 nM
Beside the measured number, compound 4's estimate is 1.3-fold (0.10 log units) above it; low and high end bracket the measured number.
By their numbers in this assay, from the lowest: compounds 4, 3, 1 and 2 (each within the scatter of the next).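

In this assay, for the compounds shown here, the step from 3-chlorophenyl to 4-fluorophenyl on a saturated chain carbon bound to an aromatic nitrogen is a 1.4-fold lower number from compound 1 to compound 4 (0.14 log units; within the scatter), the first step with a single point of difference. At this position, with the core of compound 1 held constant, this exchange therefore leaves the number within the scatter, although the step swaps the halogen and its place on the ring together and cannot separate the two. No supporting data bear on this result.

Still open, as far as these compounds go, is whether a different group at this position, such as an unsubstituted benzyl, a carboxylic acid or a primary amine on a longer chain, would give a step beyond the scatter. Also open, from the compounds shown here alone, is whether the same exchange gives a comparable step with the linker and outer aryl groups of compound 2 or compound 3.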